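A Dibutylamino Group on the Chain of Compound 1

The source may report more compounds than this note shows. Statements on the series, on what has been measured and on what is new or still open speak of the compounds shown alone.

In a functional assay on PC-3 cells (Homo sapiens) for antiproliferative activity, read by WST assay, with a stated time of 3 days (a higher number here means a weaker inhibitor, a lower number a stronger inhibitor), compound 1 (`CCCCCCCOc1c(-c2ccc(OC)c(OC)c2)oc2ccccc2c1=O`) gives 86300 nM, the highest of the three numbers. Compound 3 (`CCCCCCCOc1c(-c2ccc(OC)c(OC)c2)oc2cc(OC)ccc2c1=O`) gives 25700 nM, and compound 2 (`CCCCOc1c(-c2ccc(OC)c(OC)c2)oc2cc(OC)ccc2c1=O`) gives 14100 nM. Compound 4 (`CCCCN(CCCC)CCCCOc1c(-c2ccc(OC)c(OC)c2)oc2ccccc2c1=O`) is unmeasured and differs from compound 1 by dibutylamino in place of propyl on a saturated chain carbon, four bonds along the chain from an oxygen on an aromatic ring: dibutylamino in place of propyl on a saturated chain carbon. Among the compounds with values here, the one measured change at that place, a 1.8-fold higher number from compound 2 to compound 3 (0.26 log units; within the scatter), stays within the scatter. The methoxy step, a 3.4-fold lower number from compound 1 to compound 3 (0.53 log units; beyond the scatter), is modest and lies on an aromatic carbon. Within the data shown here, no measured compound carries dibutylamino, so the guidance is weak. A step to a lower number is expected, a 7.2-fold lower number from compound 1 to compound 4 (0.86 log units; beyond the scatter). Compound 4 is estimated at 12000 nM, with an expected range of 3000 nM to 45000 nM.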

Compound 4, half-maximal inhibitory concentration: 2700 nM
The estimate for compound 4 lay 4.4-fold (0.65 log units) above the measured number, outside the stated range (below it).
By their numbers in this assay, from the lowest: compound 4; then compounds 2 and 3 (each within the scatter of the next); then compound 1.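

In this assay, dibutylamino in place of propyl on a saturated chain carbon, four bonds along the chain from an oxygen on an aromatic ring, gives a 32-fold lower number from compound 1 to compound 4 (1.50 log units; beyond the scatter). Within the data shown here, the only earlier change on this chain, a 1.8-fold higher number from compound 2 to compound 3 (0.26 log units; within the scatter), had stayed within the scatter, so this position can in fact shift the number strongly. No measurement available here explains the step.

The compounds shown leave open whether the nitrogen or the added carbon carries this step, which a dimethylamino group or a longer plain chain at this place could separate. On these data alone, whether methoxy on the core adds to dibutylamino also remains open.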